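This account rests on a few compounds, and the source may have more. Where it says the series, first, only, none or still open, it means among the compounds named here.

Of the compounds shown here, three built on one shared core have been tested in a functional assay on CCRF-CEM cells (Homo sapiens) for inhibition, read by cell counting, with a stated time of 3 days; a lower number here means a stronger inhibitor, a higher number a weaker inhibitor. Compound 1, `COc1ccc(-c2nn3cc(-c4cccc(N)c4)nc3s2)cc1OC`, gives 14000 nM in this assay. For the measured compounds named here, compound 2, `C=C(Br)C(=O)Nc1cccc(-c2cn3nc(-c4ccc(OC)c(OC)c4)sc3n2)c1`, gives 380 nM in this assay, and the single change between them amounts to a 37-fold lower number from compound 1 to compound 2 (1.57 log units; beyond the scatter). Compound 3, `Nc1cccc(-c2cn3nc(Cc4ccc(Cl)cc4)sc3n2)c1`, gives 42000 nM in this assay, the highest of the three numbers; its gaps to compound 1 and to compound 2 both lie beyond the scatter, so among these three it is the weakest inhibitor. Going by the values given here, compound 1 and compound 3 differ in more than one place, so their two values show only that compound 3 is the weaker of the pair.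

Compound 4, `COc1ccc(Cc2nn3cc(-c4cccc(N)c4)nc3s2)cc1`, differs from compound 3 in a single place: methoxy in place of chloro on an aromatic carbon. Among the compounds with values here, no measured step bears on this part of the molecule. Within the data shown here, the one measured step alters a nitrogen on an aromatic ring elsewhere, and offers no guide to an exchange on the benzyl ring. With nothing in the measured compounds to point either way, compound 4 is expected to stay close to compound 3, and the expected step is a 1.2-fold lower number from compound 3 to compound 4 (0.08 log units; within the scatter), within the scatter. The estimate for compound 4 in this assay is 35000 nM, with a range from 12000 nM to 100000 nM.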

Compound 4, half-maximal inhibitory concentration: >= 250000 nM
Compound 4: only a limit was reported (the forecaster's own chance of this, stated with the estimate: 15%); middle value at least 7.1-fold (0.85 log units) from the limit.
By their numbers in this assay, from the lowest: compound 2; then compound 1; then compound 3. At a limit, above all of these: compound 4.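

The change from 4-chlorophenyl to 4-methoxyphenyl gives the first measured sign that the para position of this aromatic ring matters in this assay, with an at least 5.9-fold higher number from compound 3 to compound 4 (0.77 log units; beyond the scatter). For the compounds shown here, until now, the only single change with a measured effect sat on the nitrogen at the other end of the molecule, and it lowered the number, whereas this one raises it. Compound 4 gives >= 250000 nM, which is a limit of the assay and not a number. The step therefore fixes only a minimum size for the loss, not its true size, so the real gap between chloro and methoxy here remains unknown: the limit of >= 250000 nM in this assay, at which 1 of the 4 values shown sits.

The compounds shown leave open whether a plain hydrogen, a fluoro group, a methyl group or a hydroxyl group at this place would give a number closer to that of compound 3 or would also fall out of range. They also leave open whether methoxy in place of chloro would raise the number as sharply in a compound carrying the (1-bromoethenyl)carbonyl group on its nitrogen, as compound 2 does, where the starting number is much lower.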